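A few compounds are considered here, and "the series" means these few. Any claim that something is new, unique, unknown or untested is made for them only; others in the source may bear on it.

Measured compounds:
compound 1, `NCc1ccc(C(=O)Nc2ccncc2F)cc1-c1cccc(C(=O)O)c1` — > 2 h
compound 2, `CCCCCOC(=O)c1cccc(-c2cc(C(=O)Nc3ccncc3)ccc2CN)c1` — 0.967 h
compound 3, `COC(=O)c1cccc(-c2cc(C(=O)Nc3ccncc3F)ccc2CN)c1` — 1.08 h

In an ADME assay on a cell-free system (plasma, Homo sapiens) for metabolic stability, read by LC-MS (a lower number here means that the compound disappears faster, a higher number that the compound lasts longer), compound 1 gives > 2 h, and this is a limit of the assay rather than a number. Compound 1 thus stands at the limit of > 2 h in this assay, at which 1 of the 3 values shown sits, the highest point among the values shown. In this assay compound 3 gives 1.08 h, and compound 2 gives 0.967 h; these two values lie close together. Within the data shown here, the one measured step that changes a single place shows an at least 1.8-fold lower number from compound 1 to compound 3 (0.26 log units; that floor lies within the scatter).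

Compound 4, `CC(C)OCCOC(=O)c1cccc(-c2cc(C(=O)Nc3ccncc3F)ccc2CN)c1`, is not yet measured. It differs from compound 1 by 2-isopropoxyethyl in place of hydrogen on an oxygen next to a carbonyl group. This change of a carboxy to a (2-isopropoxyethoxy)carbonyl sits at the same place as the change that leads to compound 3, so a drop in half-life in this assay of a similar size is expected, an at least 2.0-fold lower number from compound 1 to compound 4 (0.30 log units; that floor lies within the scatter). Compound 4 is therefore expected to give about 1 h, with a range from 0.5 h to 2 h.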

Compound 4, half-life: 0.1 h
Beside the measured number, compound 4's estimate is 10-fold (1.00 log units) above it; measured number below the stated range.
By their numbers in this assay, from the lowest: compound 4; then compounds 2 and 3 (each within the scatter of the next). At a limit, above all of these: compound 1.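

The group on this oxygen matters, not merely the presence of an ester: in this assay, isopropoxymethyl in place of hydrogen on a saturated chain carbon bound to an oxygen next to a carbonyl group gives an 11-fold lower number from compound 3 to compound 4 (1.03 log units; beyond the scatter). The change from carboxy to (2-isopropoxyethoxy)carbonyl gives an at least 20-fold lower number from compound 1 to compound 4 (1.30 log units; beyond the scatter), a large step where the earlier step at this place reached only a floor within the scatter. Nothing measured here explains why the two esters part so widely.

The compounds shown leave open whether the loss follows the length of the chain or its ether oxygen; a plain hexyl chain and a 2-methoxyethyl group on this oxygen would separate the two. Going by these compounds, whether an amide in place of the ester would behave like either ester also stays open.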